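The source may hold more compounds than are shown below. What is called first, only, known or untested is meant among the compounds shown, and "the series" means these compounds.

Measured compounds:
- compound 1 `O=C(c1ccc(OC(F)(F)F)cc1)N1CCC(N(C2CC2)S(=O)(=O)c2cccc(C(F)(F)F)c2)CC1`: in an assay on cells for inhibition of Voltage-dependent L-type calcium channel subunit alpha-1C (Homo sapiens), read by FLIPR and calcium flux, tested at 1 uM (a higher number here means a stronger effect of the compound at the concentration tested, a lower number a weaker effect), compound 1 gives 73%
- compound 2 `O=C(c1ccccc1OC(F)(F)F)N1CCC(N(C2CC2)S(=O)(=O)c2cccc(C(F)(F)F)c2)CC1`: in this assay compound 2 gives "not determined" (no result reported)

Compound 1 and compound 2 share one core and differ only in the aromatic ring attached to the carbonyl carbon. Among the compounds with values here, compound 1 is the only one of the pair with a number in this assay, and that number is a sizeable inhibition at the tested concentration. For compound 2 no single number is available in this assay, so compound 2 stands nowhere on the scale yet, and nothing can be said about how the two compounds compare in this assay.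

Compound 3 `CN(C)c1cccc(C(=O)N2CCC(N(C3CC3)S(=O)(=O)c3cccc(C(F)(F)F)c3)CC2)c1` is the next compound and has not been measured. It differs from compound 2 in one place: 3-(dimethylamino)phenyl in place of 2-(trifluoromethoxy)phenyl on a carbonyl carbon. Within the data shown here, no step between two measured compounds is known for this kind of change, and compound 2 itself has no value, so the direction and size of the step into compound 3 cannot be taken from the data; any step, in either direction or none beyond the scatter, remains open. Taking the number of compound 1 as the only anchor, compound 3 is estimated at 50% in this assay, with an expected range from 15% to 85%.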

Compound 3, a percentage reported as inhibition, at one concentration (the size of the read-out at that concentration, not a potency): 40%
For compound 3 the middle estimate is 10 percentage points above the measured one; the range from low to high includes it.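

In this assay, the group on the carbonyl carbon now has its first readable step, as 3-(dimethylamino)phenyl in place of 4-(trifluoromethoxy)phenyl gives a number 33 percentage points lower from compound 1 to compound 3 (beyond the scatter) with the rest of the structure unchanged. This shows that the read-out at the tested concentration depends on which aromatic group stands at this place, although compound 3 still gives 40% and so keeps part of the inhibition. The compounds shown offer no measurement that accounts for the step.

Steps involving compound 2 cannot be read, since it has no number, so its 2-(trifluoromethoxy)phenyl group adds nothing to the comparison. Within the data shown here, the one readable step changes both the substituent and its numbered place on the ring, leaving their separate contributions open, along with how a 4-(dimethylamino)phenyl group, a 3-(trifluoromethoxy)phenyl group, an unsubstituted phenyl or a phenyl bearing a carboxylic acid would read on the same core.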